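The source may report more compounds than this note shows. Statements on the series, on what has been measured and on what is new or still open speak of the compounds shown alone.

Measured so far in an ADME assay on HEL cells (Homo sapiens) for cytotoxicity; a lower number here means that less compound is tolerated, a higher number that more compound is tolerated:
- compound 1 `Cc1ccc(-[n+]2noc([O-])c2CN2CCN(c3cccc(Cl)c3)CC2)cc1`: 38.2 ug/mL
- compound 2 `[O-]c1on[n+](-c2ccc(Cc3ccc(-[n+]4noc([O-])c4CN4CCCCC4)cc3)cc2)c1CN1CCCCC1`: 12.6 ug/mL
- compound 3 `Cc1ccc(-[n+]2noc([O-])c2CN2CCN(c3cccc(Cl)c3Cl)CC2)cc1`: 28.8 ug/mL

Compound 3 stands second highest of the three numbers. Its nearest neighbour is compound 1, whose number is higher but within the scatter, so no order between compound 1 and compound 3 is claimed; compound 2 lies beyond the scatter below compound 3. Within the data shown here, the only single-place step recorded is a 1.3-fold lower number from compound 1 to compound 3 (0.12 log units; within the scatter), which adds a chloro on an aromatic carbon and leaves the read-out essentially unchanged.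

Compound 4 `CC(=O)N1CCN(Cc2c([O-])on[n+]2-c2ccc(C)cc2)CC1` is not yet measured. Its difference from compound 3 is acetyl in place of 2,3-dichlorophenyl on an amine nitrogen in a ring. Among the measured compounds shown here, no measured step touches the amine nitrogen of the six-membered non-aromatic ring with 2 nitrogen; the step from compound 1 to compound 3 concerns a different part of the molecule and gives no direct guide. The change removes an aromatic ring of carbon only and 2 chlorine, and brings in 1 hydrogen-bond acceptor in a group of 3 heavy atoms. Compound 2, which also lacks an aryl on the ring nitrogen, carries two copies of the core and is not comparable in one place.

For the measured compounds named here, with no bearing step available, the expectation for compound 4 is a modest move toward a higher number, wider in range than usual; the step from compound 3 is estimated at a 1.7-fold higher number from compound 3 to compound 4 (0.24 log units; within the scatter). Compound 4 is therefore estimated at 50 ug/mL in this assay, with a range of 22 ug/mL to 115 ug/mL.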

Compound 4, half-maximal cytotoxic concentration: 24.9 ug/mL
Compound 4: the middle estimate sits 2.0-fold (0.30 log units) above what was measured; measured number inside the range.
By their numbers in this assay, from the lowest: compounds 2, 4, 3 and 1 (each within the scatter of the next, the first and the last beyond it).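

In this assay, the amine nitrogen in the six-membered non-aromatic ring with 2 nitrogen now has its first readings: acetyl in place of 2,3-dichlorophenyl gives a 1.2-fold lower number from compound 3 to compound 4 (0.06 log units; within the scatter), and acetyl in place of 3-chlorophenyl gives a 1.5-fold lower number from compound 1 to compound 4 (0.19 log units; within the scatter). Both steps lie within the scatter, so among these three compounds, replacing the six-membered aromatic ring of carbon only and its chlorine with acetyl leaves the read-out essentially unchanged. No available measurement bears on why the number holds across this change.

On these data alone, it remains open whether a hydrogen, a methyl or a benzyl on that nitrogen would also stay within the scatter of these numbers. Compound 2 differs from the others in more than one place, so its number cannot be assigned to any single change.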